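A few compounds are considered here, and "the series" means these few. Any claim that something is new, unique, unknown or untested is made for them only; others in the source may bear on it.

Measured compounds:
Compound 1, `O=C(Nc1ccc(C(F)(F)F)cc1)c1cc(Br)c(F)cc1O` — in a functional assay on HL-60 cells (Homo sapiens) for cytotoxicity, read by luminescence and CellTiter-Glo, with a stated time of 3 days (on this read-out higher numbers stand for weaker inhibition and lower numbers for stronger inhibition), compound 1 gives 450 nM.
Compound 2, `O=C(Nc1ccc(C(F)(F)F)cc1)c1cc(Br)ccc1O` — in this assay compound 2 gives 580 nM.
Compound 3, `N#Cc1ccc(NC(=O)c2ccccc2O)cc1` — in this assay compound 3 gives 4620 nM.

Compound 4, `N#Cc1ccc(NC(=O)c2cccc(F)c2O)cc1`, has not yet been measured. It differs from compound 3 by one change, (fluoro in place of hydrogen on an aromatic carbon). The same kind of change is seen between two measured compounds: compound 1 differs from compound 2 by fluoro in place of hydrogen on an aromatic carbon, and that change made a 1.3-fold lower number from compound 2 to compound 1 (0.11 log units; within the scatter). The surroundings are not identical, though. In compound 4 the entering fluoro sits ortho to a hydroxy group and meta to a large group, whereas in compound 1 it sits ortho to a bromo group, meta to a hydroxy group and para to a large group, so this is the same kind of change rather than the same change. How the core of compound 3 differs from the core of compound 2 is not broken down here.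

The step from compound 3 to compound 4 is expected to be small, a 1.2-fold lower number from compound 3 to compound 4 (0.08 log units; within the scatter), because the earlier step gave a 1.3-fold lower number from compound 2 to compound 1 (0.11 log units; within the scatter). Compound 4 is therefore estimated at 3800 nM in this assay, expected to fall between 1500 nM and 9500 nM.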

Compound 4, half-maximal inhibitory concentration: 5390 nM
Beside the measured number, compound 4's estimate is 1.4-fold (0.15 log units) below it; low and high end bracket the measured number.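

In this assay, placing fluoro on an aromatic carbon in place of hydrogen gives a 1.2-fold higher number from compound 3 to compound 4 (0.07 log units; within the scatter). Set beside the earlier case of this change, the two steps cannot be told apart: the same change on two cores in this assay, a 1.3-fold lower number (0.11 log units; within the scatter) from compound 2 to compound 1 and a 1.2-fold higher number (0.07 log units; within the scatter) from compound 3 to compound 4, 1.5-fold (0.18 log units) apart, within the scatter of two such steps On both cores, then, the swap leaves the number within the ordinary spread of repeated measurements, although the fluoro sits in different surroundings on each; this rests on only two pairs of compounds, so it does not establish that the change would behave the same way on other cores in the series or at other positions.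

The compounds shown leave open whether a different group on that same aromatic carbon, such as a chloro, a methoxy or an amine, would move the number beyond that spread. They also leave open whether any such group would behave alike on both cores, as fluoro does here.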